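Retinoid amide variants: 4-hydroxyphenyl replacing 4-hydroxybenzyl

The compounds below may be only part of what the source reports. "The series", "measured", "known", "first", "only" and "open" are said of these compounds alone.

The series rests on two measured compounds. Compound 1 `CC1=C(/C=C/C(C)=C/C=C/C(C)=C\C(=O)Nc2ccccc2)C(C)(C)CC=C1c1cccnc1` and compound 2 `CC1=C(/C=C/C(C)=C/C=C/C(C)=C\C(=O)NCc2ccc(O)cc2)C(C)(C)CCC1n1ccnc1` were both tested in a functional assay on SK-BR-3 cells (Homo sapiens) for inhibition, read by MTT assay; a higher number here means a weaker inhibitor of growth, a lower number a stronger inhibitor of growth. Compound 1 gives 47400 nM in this assay, while compound 2 gives 2450 nM, the lower of the two numbers, and the gap between them lies beyond the usual scatter. For the measured compounds named here, no single-point step connects these two compounds, so nothing is attributed to any one part of their structures.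

Compound 3 `CC1=C(/C=C/C(C)=C/C=C/C(C)=C\C(=O)Nc2ccc(O)cc2)C(C)(C)CCC1n1ccnc1` has not been measured. It differs from compound 2 in one place: 4-hydroxyphenyl in place of 4-hydroxybenzyl on an amide-type nitrogen. Going by the values given here, with no comparable step among the measured compounds, the size of this step is uncertain; a shift no larger than the scatter, or a modest weakening, is expected. Compound 3 is estimated at 3500 nM, within a range of 1000 nM to 12000 nM, the expected step being a 1.4-fold higher number from compound 2 to compound 3 (0.15 log units; within the scatter).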

Compound 3, concentration for 50% growth inhibition: 3890 nM
For compound 3 the middle estimate is 1.1-fold (0.05 log units) below the measured one, within the range that was stated.
By their numbers in this assay, from the lowest: compounds 2 and 3 (each within the scatter of the next); then compound 1.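

In this assay the series now has its first single-point step, and it reads (a 1.6-fold higher number from compound 2 to compound 3 (0.20 log units; within the scatter)), so on this amide-type nitrogen the measurement does not tell 4-hydroxyphenyl from 4-hydroxybenzyl. The change goes from the 8 heavy atoms of 4-hydroxybenzyl to the 7 of 4-hydroxyphenyl, while the six-membered aromatic ring and the counts of hydrogen-bond donors and acceptors stay the same. Nothing available explains this result.

Going by these compounds, it remains open whether a longer chain on the same nitrogen, such as 2-(4-hydroxyphenyl)ethyl, or an amine or a carboxylic acid in place of the hydroxyl, would give a number in the same range. For the compounds shown here, compound 1 is still joined to the others by no single-point step, so no part of its structure can be linked to its value.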